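Swapping bromo for methoxy on the phenyl of a thiazolidinedione series

The compounds below may be only part of what the source reports. "The series", "measured", "known", "first", "only" and "open" are said of these compounds alone.

Measured so far:
compound 1, `O=C1NC(=O)/C(=C/c2ccc(OCCSc3nnc(-c4ccccc4)[nH]3)cc2)S1`: 38.9%
compound 2, `Cc1ccc(-c2nnc(SCCOc3ccc(/C=C4\SC(=O)NC4=O)cc3)[nH]2)cc1`: 54%
compound 3, `O=C1NC(=O)/C(=C/c2ccc(OCCSc3nnc(-c4ccc(Br)cc4)[nH]3)cc2)S1`: 45.7%

In a functional assay on the whole organism (strain Wistar) with Rattus norvegicus as the target, with a stated time of 15 days, at a dose of 100 mg/kg by the oral route (a higher number here means a stronger effect of the compound at the dose given, a lower number a weaker effect), compound 3 stands second highest of the three numbers, yet both of its neighbours lie within the usual scatter of it: a number 8.3 percentage points lower from compound 2 to compound 3 (within the scatter) and a number 6.8 percentage points higher from compound 1 to compound 3 (within the scatter). Going by the values given here, only one step here is beyond the scatter, a number 15.1 percentage points higher from compound 1 to compound 2 (beyond the scatter), where the shared core gains a methyl.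

Compound 4, `COc1ccc(-c2nnc(SCCOc3ccc(/C=C4\SC(=O)NC4=O)cc3)[nH]2)cc1`, has not yet been measured. It differs from compound 3 by methoxy in place of bromo on an aromatic carbon. Among the compounds with values here, no measured pair swaps bromo for methoxy, so the nearest guidance is that substituents at this position have moved the read-out only modestly: bromo did little, methyl somewhat more. Compound 4 is therefore expected to sit close to compound 3, with a step of about a number 4.3 percentage points higher from compound 3 to compound 4 (within the scatter) in this assay, not clearly beyond the scatter in either direction. The estimate for compound 4 is 50%, within a range from 35% to 65%.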

Compound 4, a percentage reported as activity, at one dose (the size of the read-out at that dose, not a potency): 71.2%
For compound 4 the middle estimate is 21.2 percentage points below the measured one; the measured number lies above the stated range.
By their numbers in this assay, from the lowest: compounds 1, 3 and 2 (each within the scatter of the next, the first and the last beyond it); then compound 4.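

In this assay the 4-bromophenyl to 4-methoxyphenyl change gives a number 25.5 percentage points higher from compound 3 to compound 4 (beyond the scatter); methoxy also stands clear of the other two groups at this position, with a number 17.2 percentage points higher from compound 2 to compound 4 (beyond the scatter) and a number 32.3 percentage points higher from compound 1 to compound 4 (beyond the scatter). The earlier compounds shown here showed only a modest gain from hydrogen to methyl and no clear separation of bromo from methyl, whereas compound 4 is now the strongest of the four at this dose, so this position can produce a much larger difference than those compounds suggested. No measurement here explains why methoxy stands out.

On these data alone, it remains open whether an ethoxy group, a hydroxy group or an amine in the same place would match compound 4. As far as these compounds go, each number also describes a single dose, so how the compounds compare across other doses is unknown.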